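This account rests on a few compounds, and the source may have more. Where it says the series, first, only, none or still open, it means among the compounds named here.

In a functional assay on SGC-7901 cells (Homo sapiens) for antiproliferative activity, read by MTT assay, with a stated time of 24 h (on this read-out lower numbers stand for stronger inhibition and higher numbers for weaker inhibition), compound 1 `O=C(NNc1ccccc1Cl)c1ccc(NS(=O)(=O)c2cnc(O)nc2O)cc1` gives 3630 nM, while compound 2 `O=C(NNc1cccc(Cl)c1)c1cccc(NS(=O)(=O)c2cnc(O)nc2O)c1` gives 11800 nM. Compound 2 thus has the higher of the two numbers, and the gap between them lies beyond the usual scatter. Compound 3 `O=C(NNc1ccccc1Cl)c1ccccc1NS(=O)(=O)c1cnc(O)nc1O` is reported only as a limit of this assay, > 20000 nM. Compound 4 `Cc1ccc(C(=O)NNC(=O)c2cccc(NS(=O)(=O)c3cnc(O)nc3O)c2)cc1` carries (4-methylphenyl)carbonyl in place of 3-chlorophenyl on an amine nitrogen of compound 2: (4-methylphenyl)carbonyl in place of 3-chlorophenyl on an amine nitrogen. For the measured compounds named here, no measured pair of compounds shows this change, so the expectation starts from compound 2 at 11800 nM. The expected step, a 1.2-fold lower number from compound 2 to compound 4 (0.07 log units; within the scatter), is small and stays within the scatter. For compound 4 the estimated value is 10000 nM, with an expected range of 3500 nM to 28000 nM.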

Compound 4, half-maximal inhibitory concentration: 10100 nM
Beside the measured number, compound 4's estimate is 1.0-fold (0.00 log units) below it; measured number inside the range.
By their numbers in this assay, from the lowest: compound 1; then compounds 4 and 2 (each within the scatter of the next). At a limit, above all of these: compound 3.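

In this assay the step reads a 1.2-fold lower number from compound 2 to compound 4 (0.07 log units; within the scatter) and so shows that this amine nitrogen can carry a (4-methylphenyl)carbonyl group instead of 3-chlorophenyl without a shift beyond the scatter. The position thus holds an entering group with a carbonyl and more heavy atoms, and the aromatic ring is kept in both groups. None of the information given here accounts for this outcome. As far as these compounds go, whether a carboxylic acid or an amine on that ring would move the number remains open. So does the effect of a longer chain in its place.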